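A few compounds are considered here, and "the series" means these few. Any claim that something is new, unique, unknown or untested is made for them only; others in the source may bear on it.

Compound 1 `Cc1cccc(NC(=O)C(F)(F)C(F)(F)C(F)(F)C(F)(F)C(F)(F)C(F)(F)C(=O)NO)c1` and compound 2 `O=C(NO)C(F)(F)C(F)(F)C(F)(F)C(F)(F)C(F)(F)C(F)(F)C(=O)Nc1ccc(I)cc1` share the same core and differ only in the aryl group on the amide nitrogen. In an ADME assay on isolated protein for inhibition of histone deacetylase 5 (Homo sapiens), read by fluorescence, with stated times of 30 min and 60 min (a lower number here means a stronger inhibitor, a higher number a weaker inhibitor), compound 1 reaches only the limit of > 50000 nM. In this assay compound 2 also reaches only the limit of > 50000 nM. The step that the two limits leave unreadable from compound 1 to compound 2 is thus unreadable, and the limit of > 50000 nM in this assay, at which 2 of the 2 values shown sit, is all that bears on compound 3 `CC(=O)Nc1ccc(NC(=O)C(F)(F)C(F)(F)C(F)(F)C(F)(F)C(F)(F)C(F)(F)C(=O)NO)cc1`. Compound 3 carries acetamido in place of iodo on an aromatic carbon. For the measured compounds named here, with both measured values at a limit, no step in this assay is readable beyond the scatter. Compound 3 is expected to sit at that limit too, estimated at 60000 nM with a range from 20000 nM to 200000 nM. That expected step is a step that the limit leaves unreadable from compound 2 to compound 3.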

Compound 3, inhibition constant: > 50000 nM
Compound 3: only a limit was reported; the forecaster's own chance of this, stated with the estimate: 80%; the middle value does not contradict the limit.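

In this assay compound 3 gives > 50000 nM as a limit and not a number. For the compounds shown here, no new step among compound 1, compound 2 and compound 3 can be read. In this assay these compounds leave open whether any aryl group on the shared core gives a readable inhibition constant.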